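The compounds below may be only part of what the source reports. "The series", "measured", "known", "first", "only" and "open" are said of these compounds alone.

Of the compounds shown here, three have been measured in a functional assay on MCF7 cells (Homo sapiens) for antiproliferative activity, read by MTT assay, with a stated time of 72 h; a lower number here means a stronger inhibitor, a higher number a weaker inhibitor. Compound 1, `COc1ccc(N2C(=O)COc3ccc(-c4cnc(OC)c(NS(=O)(=O)c5ccc(F)cc5)c4)cc32)cc1`, gives 8260 nM and holds the lowest number of the three. Compound 2, `COc1ccc(N2C(=O)COc3ccc(-c4ccc(O)cc4)cc32)cc1`, gives 17300 nM, which stands above compound 1 by more than the scatter. Compound 3, `Cc1ccc(N2C(=O)COc3ccc(-c4cnc(Cl)c(NS(=O)(=O)c5ccc(F)cc5)c4)cc32)cc1`, gives 32600 nM, the highest of the set and again beyond the scatter from compound 1. No two of these compounds differ in a single place, so no single-point step is available to lean on.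

Compound 4, `COc1ncc(-c2ccc3c(c2)NC(=O)CO3)cc1NS(=O)(=O)c1ccc(F)cc1`, differs from compound 1 in one place: hydrogen in place of 4-methoxyphenyl on an amide-type nitrogen in a ring. The 4-methoxyphenyl group leaves and a hydrogen takes its place on the amide-type nitrogen in the ring. Going by the values given here, nothing among the measured compounds tells how this assay answers such a change, so any expectation rests on the change alone. A step somewhat beyond the scatter towards a weaker inhibitor is expected, written as a 1.8-fold higher number from compound 1 to compound 4 (0.26 log units; within the scatter). Compound 4 is estimated to give 15000 nM in this assay, within a range from 4000 nM to 60000 nM.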

Compound 4, half-maximal inhibitory concentration: 32300 nM
For compound 4 the middle estimate is 2.2-fold (0.33 log units) below the measured one, within the range that was stated.
By their numbers in this assay, from the lowest: compound 1; then compounds 2, 4 and 3 (each within the scatter of the next).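

Going by these compounds alone, this is the first step in the set that isolates a single place: on the amide-type nitrogen in the ring, hydrogen in place of 4-methoxyphenyl gives a 3.9-fold higher number from compound 1 to compound 4 (0.59 log units; beyond the scatter) in this assay. The earlier compounds shown here could not separate the contribution of this substituent from changes elsewhere, whereas this pair shows that, on the core of compound 1, the 4-methoxyphenyl group goes with the stronger inhibitor, although this rests on one pair. Nothing available explains why the number rises when this group is lost.

On these data alone, what remains open is whether the whole 4-methoxyphenyl group is needed at this nitrogen, or whether a plain phenyl, a benzyl or a simple methyl would hold the value of compound 1. As far as these compounds go, it is also open whether the same step would appear on a different core.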